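Substituent series on the shared core: acetyl to 1-hydroxyethyl

A few compounds are considered here, and "the series" means these few. Any claim that something is new, unique, unknown or untested is made for them only; others in the source may bear on it.

In a functional assay on cells for agonist activity at Glucose-dependent insulinotropic receptor (Homo sapiens), read by a luciferase reporter, with a stated time of 4 h (a lower number here means that less compound is needed, a higher number that more compound is needed for the effect), compound 3 `CC(=O)c1cnc(N2CCC(c3coc4c(N5CCc6cc(S(C)(=O)=O)ccc65)ncnc34)CC2)nc1` gives 78 nM, the lowest of the three numbers. Compound 1 `Cc1cnc(N2CCC(c3coc4c(N5CCc6cc(S(C)(=O)=O)ccc65)ncnc34)CC2)nc1` gives 252 nM and compound 2 `CS(=O)(=O)c1ccc2c(c1)CCN2c1ncnc2c(C3CCN(c4ncccn4)CC3)coc12` gives 512 nM. The steps of a 3.2-fold lower number from compound 1 to compound 3 (0.51 log units; beyond the scatter) and a 6.6-fold lower number from compound 2 to compound 3 (0.82 log units; beyond the scatter) both favour the acetyl group on this ring. Compound 4 `CC(O)c1cnc(N2CCC(c3coc4c(N5CCc6cc(S(C)(=O)=O)ccc65)ncnc34)CC2)nc1` carries 1-hydroxyethyl in place of acetyl on an aromatic carbon. Going by the values given here, no measured step covers this change: the carbonyl leaves and a hydrogen-bond donor enters, without precedent in the set. The two steps into compound 3 show that the acetyl group is the best of the three substituents tried, so some loss on its removal is plausible but not quantified. Compound 4 is expected at 160 nM, with a range of 60 nM to 420 nM. The expected step is a 2.1-fold higher number from compound 3 to compound 4 (0.31 log units; beyond the scatter), a modest rise.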

Compound 4, half-maximal effective concentration: 586 nM
Compound 4: the middle estimate sits 3.7-fold (0.56 log units) below what was measured; the whole stated range lies below it.
By their numbers in this assay, from the lowest: compound 3; then compound 1; then compounds 2 and 4 (each within the scatter of the next).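

In this assay, swapping acetyl for 1-hydroxyethyl removes the whole advantage of the acetyl group (a 7.5-fold higher number from compound 3 to compound 4 (0.88 log units; beyond the scatter)). The new group also falls short of methyl (a 2.3-fold higher number from compound 1 to compound 4 (0.37 log units; beyond the scatter)) and is level with plain hydrogen (a 1.1-fold higher number from compound 2 to compound 4 (0.06 log units; within the scatter)), so among the groups shown, the gain at this position goes with acetyl alone. Nothing measured on these compounds explains the loss.

Still open, going by these compounds, is whether other carbonyl groups, such as a methyl ester or a primary amide, keep the gain. Also open, on these data alone, is whether 1-methoxyethyl, the methyl ether of the new group, recovers any of it.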